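Lengthening the amide acyl group on a trimethoxyphenyl anilide

This account rests on a few compounds, and the source may have more. Where it says the series, first, only, none or still open, it means among the compounds named here.

Of the compounds shown here, three have been measured in a functional assay on HCT-116 cells (Homo sapiens) for inhibition, read by MTT assay, with a stated time of 48 h; on this read-out higher numbers stand for weaker inhibition and lower numbers for stronger inhibition. Compound 1, `COc1ccc(CN(C(=O)C2CC2)c2cc(OC)c(OC)c(OC)c2)cc1O`, is the anilide with a cyclopropylcarbonyl on its nitrogen; in this assay compound 1 gives 49 nM, the lowest of the three numbers. Compound 2, `C/C=C/C(=O)N(Cc1ccc(OC)c(Cl)c1)c1cc(OC)c(OC)c(OC)c1`, gives 1420 nM in this assay, and compound 3, `COc1ccc(CNc2cc(OC)c(OC)c(OC)c2)cc1Cl`, gives 41700 nM. Compound 1 differs from compound 2 in more than one place, so their values are simply noted side by side. For the measured compounds named here, the one single-point step in the set is a 29-fold higher number from compound 2 to compound 3 (1.47 log units; beyond the scatter), which shows that removing the acyl group from the nitrogen altogether costs a great deal.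

The next compound, compound 4, `CCCCC(=O)N(Cc1ccc(OC)c(O)c1)c1cc(OC)c(OC)c(OC)c1`, differs from compound 1 in one place:

butyl in place of cyclopropyl on a carbonyl carbon

Going by the values given here, no measured pair changes the size of the acyl group while keeping it present, so the step from compound 2 to compound 3 bears on it only indirectly: it shows the acyl group matters, not which one. The expectation is therefore a small step, if any, beyond the scatter, leaning toward a somewhat higher number. Compound 4 is expected to give about 100 nM in this assay, within 30 nM to 400 nM, which means an estimated step of a 2.0-fold higher number from compound 1 to compound 4 (0.31 log units; beyond the scatter).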

Compound 4, half-maximal inhibitory concentration: 170 nM
The estimate for compound 4 lay 1.7-fold (0.23 log units) below the measured number; measured number inside the range.
By their numbers in this assay, from the lowest: compound 1; then compound 4; then compound 2; then compound 3.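

In this assay, putting butyl in place of cyclopropyl on the carbonyl carbon gives a 3.5-fold higher number from compound 1 to compound 4 (0.54 log units; beyond the scatter), a modest step but one beyond the scatter. For the compounds shown here, this is the first pair in which the acyl group stays on the amide-type nitrogen and only its carbon part changes, so it shows that the number depends on which group is carried there. The earlier step, a 29-fold higher number from compound 2 to compound 3 (1.47 log units; beyond the scatter), showed only what happens when the acyl group is removed altogether, and nothing measured here explains the new difference.

Going by these compounds alone, the single change replaces a three-membered ring of carbon with an open chain and also goes from 3 heavy atoms to 4, so the pair cannot separate the loss of the ring from the change in size. On these data alone, it remains open how a propyl chain, a longer chain such as hexyl, or a cyclobutyl ring would stand on the same carbonyl carbon, and whether the step from cyclopropyl to butyl would keep its size on the core of compound 2.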